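Compound 3: methyl on the methoxy-bearing ring

The source may report more compounds than this note shows. Statements on the series, on what has been measured and on what is new or still open speak of the compounds shown alone.

Measured so far:
Compound 1 `Cc1cc(-c2nc3ccccc3s2)ccc1N`: > 100000 nM (a limit)
Compound 2 `COc1ccc(-c2nc3cc(F)ccc3s2)cc1`: 12400 nM

Going by the values given here, in a functional assay on HCC 2998 cells (Homo sapiens) for antiproliferative activity (on this read-out lower numbers stand for stronger inhibition of growth and higher numbers for weaker inhibition of growth), compound 2 gives 12400 nM, the only actual number so far. Compound 1 is recorded at > 100000 nM, which is a limit of the assay and not a number. Compound 2 therefore has no second number to be ranked against.

Compound 3 `COc1ccc(-c2nc3cc(F)ccc3s2)cc1C` differs from compound 2 in one place: methyl in place of hydrogen on an aromatic carbon. This is a methyl in place of hydrogen on an aromatic carbon, ortho to a methoxy group.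

Among the compounds with values here, no two measured compounds differ in one place only, so the series offers no measured size for a change of this kind. The expectation in this assay is therefore loose: a moderate shift toward stronger inhibition of growth, with a result within the scatter still possible. The expected change is a 3.1-fold lower number from compound 2 to compound 3 (0.49 log units; beyond the scatter). For compound 3 the estimated value is 4000 nM, with an expected range from 300 nM to 30000 nM.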

Compound 3, concentration for 50% growth inhibition: 540 nM
Compound 3: the middle estimate sits 7.4-fold (0.87 log units) above what was measured; the range from low to high includes it.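

In this assay, the series now has its first step between compounds that differ in one place, and it is a 23-fold lower number from compound 2 to compound 3 (1.36 log units; beyond the scatter) for methyl in place of hydrogen on an aromatic carbon. This shows that the position ortho to a methoxy group and meta to a large group is not indifferent in this series: a change of 1 heavy atom, with no ring, no hydrogen-bond donor or acceptor and no net charge, moves the read-out well beyond the scatter. Nothing among the data shown accounts for the size of this step.

From the compounds shown here alone, with a single step at this carbon, it remains open whether the gain is specific to methyl or would also appear with a larger or different group there, such as ethyl, chlorine, hydroxyl or an amine. Going by these compounds, it is equally open whether the step carries over when the neighbouring methoxy gives way to another group, such as ethoxy or a carboxylic acid, or when the fluorine on the shared core is replaced.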